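From Compound 1 to Compound 3: A Shorter Chain

This account rests on a few compounds, and the source may have more. Where it says the series, first, only, none or still open, it means among the compounds named here.

- Compound 1 `COc1cc(/C=C/C=O)cc(OC)c1OC/C=C(\C)CCC=C(C)C` gives 39000 nM
- Compound 2 `C=C(C)CCOc1c(OC)cc(/C=C/CO)cc1OC` gives > 100000 nM as a limit of the assay

Both results come from a functional assay on PC-3 cells (Homo sapiens) for cytotoxicity, read by MTT assay, with a stated time of 72 h (a higher number here means a weaker inhibitor, a lower number a stronger inhibitor), and give a first view of this small set. Within the data shown here, compound 1 holds the only actual number so far, and a higher number here means weaker action on the cells. Compound 2 has a limit and not a number.

The next compound to be tested is compound 3 `COc1cc(/C=C/C=O)cc(OC)c1OCC=C(C)C`, which keeps the core of compound 1 but carries a shorter chain. The change is hydrogen in place of 3-methylbut-2-en-1-yl on a saturated chain carbon bound to a double-bonded chain carbon.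

Among the measured compounds shown here, no two measured compounds differ in just one place, so no measured step can guide the size of this one. In this assay a modest move toward weaker action is expected, perhaps only a little beyond the usual scatter. The expected change is a 1.7-fold higher number from compound 1 to compound 3 (0.22 log units; within the scatter), and this is only an estimate. For compound 3 the estimated value is 65000 nM, with an expected range from 28000 nM to 100000 nM.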

Compound 3, half-maximal inhibitory concentration: 28000 nM
The estimate for compound 3 lay 2.3-fold (0.37 log units) above the measured number; the range from low to high includes it.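

In this assay, hydrogen in place of 3-methylbut-2-en-1-yl on a saturated chain carbon bound to a double-bonded chain carbon gives a 1.4-fold lower number from compound 1 to compound 3 (0.14 log units; within the scatter). Among these compounds, this is the first step in the set that can be read, as compound 1 and compound 3 differ in one place only, and it shows that a group of 5 carbon atoms with its double bond can leave this place with no change beyond the usual scatter, so the two compounds count as alike in this test. Nothing among the data shown offers a reason for this result.

On these data alone, what a longer chain, an amine or a carboxylic acid would do at this same place remains open, since a single step within the scatter says nothing about other groups. Compound 2 gives > 100000 nM, which is a limit of the assay and not a number, and it differs from compound 1 in more than one place, so it adds no readable step.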